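Chloro on the sulfonyl ring across two cores

The source may hold more compounds than are shown below. What is called first, only, known or untested is meant among the compounds shown, and "the series" means these compounds.

Compound 1 `Cc1ccc(C2CN(S(=O)(=O)c3ccccc3)C(=O)N2)cc1` and compound 2 `Cc1ccc(C2CN(S(=O)(=O)c3ccc(Cl)cc3)C(=O)N2)cc1` share one core; compound 3 `Cc1ccc(C2CNC(=O)N2S(=O)(=O)c2ccccc2)cc1` and the not yet measured compound 4 `Cc1ccc(C2CNC(=O)N2S(=O)(=O)c2ccc(Cl)cc2)cc1` share another. The difference between the two cores is not broken down here. In a functional assay on A549 cells (Homo sapiens) for cytotoxicity (on this read-out lower numbers stand for stronger inhibition and higher numbers for weaker inhibition), compound 1 gives a limit of the assay, > 316000 nM. Compound 2 gives 158000 nM in this assay, and compound 3 gives 157000 nM; these two sit within the scatter of each other. The change from compound 1 to compound 2 is chloro in place of hydrogen on an aromatic carbon and it produced an at least 2.0-fold lower number from compound 1 to compound 2 (0.30 log units; that floor lies within the scatter); that floor follows because the limit of > 316000 nM in this assay, at which 1 of the 3 values shown sits, holds for compound 1. Compound 4 carries the same change against compound 3, (chloro in place of hydrogen on an aromatic carbon), with the place described in the same words. The expected step of a 2.0-fold lower number from compound 3 to compound 4 (0.29 log units; within the scatter) rests on the single shown step an at least 2.0-fold lower number from compound 1 to compound 2 (0.30 log units; that floor lies within the scatter) and is taken to be of about that size. Compound 3 starts from a number, 157000 nM, not a limit, so the expected step should be visible. Compound 4 is estimated at 80000 nM, between 30000 nM and 250000 nM.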

Compound 4, half-maximal inhibitory concentration: 266000 nM
Compound 4: middle estimate off by 3.3-fold (0.52 log units), on the low side; measured number above the stated range.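

In this assay, chloro in place of hydrogen on an aromatic carbon of the sulfonyl ring does not carry over from one core to the other as a step of constant size: the same change on two cores in this assay, an at least 2.0-fold lower number (0.30 log units; that floor lies within the scatter) from compound 1 to compound 2 and a 1.7-fold higher number (0.23 log units; within the scatter) from compound 3 to compound 4, at least 3.3-fold (0.53 log units) apart, beyond the scatter of two such steps Taken alone, the new step, a 1.7-fold higher number from compound 3 to compound 4 (0.23 log units; within the scatter), cannot be told from repeat scatter, and a single pair on each core gives neither a general rule for the series nor a reason for the gap. Compound 1 stands at a limit of the assay, so the size of the earlier step remains unknown and only its floor can enter the comparison: the limit of > 316000 nM in this assay, at which 1 of the 4 values shown sits.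

Still open, from the compounds shown here alone, is whether other groups at the same place on the sulfonyl ring, such as fluoro, methoxy or an amine, also differ between the two cores. Also open, going by these compounds, is how either core responds when a carboxylic acid or a longer chain replaces the methyl group.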